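From pyridin-3-yl to pyridin-4-yl in compound 4

This account rests on a few compounds, and the source may have more. Where it says the series, first, only, none or still open, it means among the compounds named here.

Measured in an ADME assay on Caco-2 cells (Homo sapiens) for permeability, in the apical to basolateral direction, with a stated time of 60 min, tested at 10 uM; a higher number here means that the compound crosses the layer faster, a lower number that the compound crosses the layer more slowly:
Compound 1 `CNC(=O)[C@@H](NC(=O)[C@@](O)(CCCN(Cc1ccc(Br)cc1)NC(=O)[C@@H](NC(=O)OC)C(C)(C)C)Cc1ccccc1)C(C)(C)C` gives 4.6 10^-6 cm/s
Compound 2 `CNC(=O)[C@@H](NC(=O)[C@@](O)(CCCN(Cc1ccc(-c2ccccc2)cc1)NC(=O)[C@@H](NC(=O)OC)C(C)(C)C)Cc1ccccc1)C(C)(C)C` gives 21 10^-6 cm/s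
Compound 3 `CNC(=O)[C@@H](NC(=O)[C@@](O)(CCCN(Cc1ccc(-c2cccnc2)cc1)NC(=O)[C@@H](NC(=O)OC)C(C)(C)C)Cc1ccccc1)C(C)(C)C` gives < 1 10^-6 cm/s

Compound 3 stands at the limit of < 1 10^-6 cm/s in this assay, at which 1 of the 3 values shown sits. This is a limit and not a number.

Compound 4 `CNC(=O)[C@@H](NC(=O)[C@@](O)(CCCN(Cc1ccc(-c2ccncc2)cc1)NC(=O)[C@@H](NC(=O)OC)C(C)(C)C)Cc1ccccc1)C(C)(C)C` differs from compound 3 by a single exchange, (pyridin-4-yl in place of pyridin-3-yl on an aromatic carbon), with pyridin-4-yl in place of pyridin-3-yl on an aromatic carbon, para to a large group. Within the data shown here, no measured step makes this exchange. The closest evidence is an at least 21-fold lower number from compound 2 to compound 3 (1.32 log units; beyond the scatter), together with an at least 4.6-fold lower number from compound 1 to compound 3 (0.66 log units; beyond the scatter). Set against these is a 4.6-fold higher number from compound 1 to compound 2 (0.66 log units; beyond the scatter). Both steps that bring in pyridin-3-yl lead down in this assay, and compound 4 also carries a pyridine ring, so it is expected to stay close to compound 3 rather than return towards compound 2. The expected change is a number no lower from compound 3 to compound 4 (the limit leaves the size open), which is estimated to lie within the scatter. For compound 4 the estimate is 1 10^-6 cm/s, with an expected range of 0.4 10^-6 cm/s to 4 10^-6 cm/s.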

Compound 4, apparent permeability: 1.9 10^-6 cm/s
Beside the measured number, compound 4's estimate is 1.9-fold (0.28 log units) below it, within the range that was stated.
By their numbers in this assay, from the lowest: compound 4; then compound 1; then compound 2. At a limit, below all of these: compound 3.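

In this assay, the fall that came with pyridin-3-yl in place of phenyl is not confined to that one pyridine: pyridin-4-yl in the same place gives an 11-fold lower number from compound 2 to compound 4 (1.04 log units; beyond the scatter), and against bromo it gives a 2.4-fold lower number from compound 1 to compound 4 (0.38 log units; beyond the scatter). The exchange between the two pyridines gives an at least 1.9-fold higher number from compound 3 to compound 4 (0.27 log units; that floor lies within the scatter), and as that floor lies within the scatter, no difference between them is established. Compound 3 has a limit here and not a number: the limit of < 1 10^-6 cm/s in this assay, at which 1 of the 4 values shown sits.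

The compounds shown leave open whether pyridin-2-yl, or a phenyl ring carrying an amine or a carboxylic acid at this place, would read like compound 2 or like compound 4. As far as these compounds go, whether these steps would hold on a core other than that of compound 1 also stays open.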